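Dicarboxyethyl amides: inverting the chain stereocentre

The source may report more compounds than this note shows. Statements on the series, on what has been measured and on what is new or still open speak of the compounds shown alone.

Measured in a functional assay on PC-3 cells (Homo sapiens) for antiproliferative activity, read by MTT assay, with a stated time of 24 h; on this read-out higher numbers stand for weaker inhibition and lower numbers for stronger inhibition:
- Compound 1 `CCn1c(C(=O)NC2(CO)CC2)ccc1C(CC)(CC)c1ccc(OCS(=O)(=O)c2ccccc2)c(C)c1`: 3560 nM
- Compound 2 `CCn1c(C(=O)N[C@@H](CC(=O)O)C(=O)O)ccc1C(CC)(CC)c1ccc(OCS(=O)(=O)c2ccccc2)c(C)c1`: > 50000 nM (a limit, not a number)

Compound 2 stands at the limit of > 50000 nM in this assay, at which 1 of the 2 values shown sits. Compound 3 `CCn1c(C(=O)N[C@H](CC(=O)O)C(=O)O)ccc1C(CC)(CC)c1ccc(OCS(=O)(=O)c2ccccc2)c(C)c1` is still unmeasured, and its relation to compound 2 is simple: the two compounds have the same atoms and bonds and differ only in configuration as drawn: 1 of 1 stereo elements differ; a stereocentre at a saturated chain carbon is drawn S in compound 2 and R in compound 3.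

Within the data shown here, no measured step changes configuration alone, so the size of this change cannot be read directly. The nearest evidence is an at least 14-fold higher number from compound 1 to compound 2 (1.14 log units; beyond the scatter), a large step beyond the scatter that came with the 1,2-dicarboxyethyl group. Compound 3 keeps that group, so a return towards the value of compound 1 is not expected, and a second reading at the limit is likely in this assay. The estimated size is a number no higher from compound 2 to compound 3 (the limit leaves the size open). For compound 3 the expected value is 50000 nM, with an estimated range of 20000 nM to 100000 nM.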

Compound 3, half-maximal inhibitory concentration: > 50000 nM
Compound 3 gave a limit, no number; the forecaster's own chance of this, stated with the estimate: 75%; the middle value lies on the limit itself.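

In this assay compound 3 gives > 50000 nM, a limit and not a number. With the chain stereocentre drawn R, the 1,2-dicarboxyethyl group still comes with an at least 14-fold higher number from compound 1 to compound 3 (1.14 log units; beyond the scatter), so the large step does not depend on the S configuration of compound 2. The step between compound 2 and compound 3 cannot be read, as both configurations now sit at the same limit: the limit of > 50000 nM in this assay, at which 2 of the 3 values shown sit.

The compounds shown leave open whether the two configurations differ at all in this assay, and how far past the limit each one lies. They also leave open what a methyl ester or an amine in place of the two carboxylic acids would give on the same amide nitrogen.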